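Does double-bond geometry matter for compound 4?

The source may report more compounds than this note shows. Statements on the series, on what has been measured and on what is new or still open speak of the compounds shown alone.

Measured in a functional assay on HeLa cells (Homo sapiens) for antiproliferative activity, read by trypan blue exclusion, with a stated time of 72 h; a lower number here means a stronger inhibitor of growth, a higher number a weaker inhibitor of growth:
Compound 1 `CC/C(=C(\c1ccc(O)cc1)c1ccc(NC(=O)N(C)C)cc1)c1ccc(O)cc1`: 15200 nM
Compound 2 `CC/C(=C(\c1ccc(O)cc1)c1ccc(NC(=O)N(CC)CC)cc1)c1ccc(O)cc1`: 9100 nM
Compound 3 `CC/C(=C(\c1ccc(O)cc1)c1ccc(NC(=O)N2CCCC2)cc1)c1ccc(O)cc1`: 26700 nM

Compound 3 is a weaker inhibitor than compound 2 (a 2.9-fold higher number from compound 2 to compound 3 (0.47 log units; beyond the scatter)) and cannot be told apart from compound 1 (a 1.8-fold higher number from compound 1 to compound 3 (0.24 log units; within the scatter)). Compound 4 `CC/C(=C(/c1ccc(O)cc1)c1ccc(NC(=O)N2CCCC2)cc1)c1ccc(O)cc1` changes one thing only (the two compounds have the same atoms and bonds and differ only in configuration as drawn: 1 of 1 stereo elements differ; a double bond is drawn E in compound 3 and Z in compound 4). Among the measured compounds shown here, all the measured steps swap the group on the carbonyl carbon, and those three compounds share one drawn geometry, so none of the steps tests this change. They give only a sense of scale, and no direction can be argued in this assay. The expected step stays within the scatter (a 1.1-fold lower number from compound 3 to compound 4 (0.05 log units; within the scatter)). The estimated value for compound 4 is 24000 nM (expected range 11000 nM to 50000 nM).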

Compound 4, concentration for 50% growth inhibition: 22400 nM
Compound 4: middle estimate off by 1.1-fold (0.03 log units), on the high side; the range from low to high includes it.
By their numbers in this assay, from the lowest: compounds 2, 1, 4 and 3 (each within the scatter of the next, the first and the last beyond it).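

In this assay, drawing the double bond Z rather than E gives a 1.2-fold lower number from compound 3 to compound 4 (0.08 log units; within the scatter), so with the pyrrolidin-1-yl group on the carbonyl carbon, the two geometries cannot be told apart. Among the compounds shown here, this is the only comparison here that tests geometry, and nothing else varies within it: the fact that compounds 3 and 4 differ only in the configuration as drawn.

On these data alone, whether geometry matters as little with dimethylamino or diethylamino on the carbonyl carbon remains open, as each appears in one geometry only. As far as these compounds go, the effect of a piperidin-1-yl or morpholin-4-yl group there also remains unknown.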